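The compounds below may be only part of what the source reports. "The series", "measured", "known", "first", "only" and "open" are said of these compounds alone.

Compound 3 `COc1cc(/C=C/C(=O)c2ccc(OC)c([N+](=O)[O-])c2)cc(OC)c1` carries a nitro group on the ring bearing the carbonyl, while compound 1 `COc1cccc(/C=C/C(=O)c2ccc(OC)c([N+](=O)[O-])c2)c1` lacks the second methoxy group on the other ring. In a functional assay on B16 cells (Mus musculus) for cytotoxicity, read by MTT assay, with a stated time of 3 days (on this read-out higher numbers stand for weaker inhibition and lower numbers for stronger inhibition), compound 1 gives only a limit, > 100000 nM. Compound 2 `COc1cccc(/C=C/C(=O)c2ccc(OC)c(N)c2)c1` is the amino counterpart of compound 1; in this assay compound 2 gives 33000 nM. Going by the values given here, compound 3 gives 5600 nM in this assay, the lower of the two measured numbers and thus the most potent compound so far. The step from compound 1 to compound 3, methoxy in place of hydrogen, showed an at least 17-fold lower number from compound 1 to compound 3 (1.25 log units; beyond the scatter). Compound 4 `COc1cc(/C=C/C(=O)c2ccc(OC)c(N)c2)cc(OC)c1` differs from compound 3 in one place: amino in place of nitro on an aromatic carbon. The same exchange has already been made once, from compound 1 to compound 2, where it gave an at least 3.0-fold lower number from compound 1 to compound 2 (0.48 log units; beyond the scatter); because that step starts at the limit of > 100000 nM in this assay, at which 1 of the 3 values shown sits, its true size is only bounded from below. On that evidence, compound 4 is expected to show a modest drop in number from compound 3, a 2.8-fold lower number from compound 3 to compound 4 (0.45 log units; beyond the scatter), so compound 4 is estimated at 2000 nM, likely between 500 nM and 8000 nM.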

Compound 4, half-maximal inhibitory concentration: 8800 nM
For compound 4 the middle estimate is 4.4-fold (0.64 log units) below the measured one; measured number outside the range, above it.
By their numbers in this assay, from the lowest: compounds 3 and 4 (each within the scatter of the next); then compound 2. At a limit, above all of these: compound 1.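

On the core of compound 3, amino in place of nitro in this assay gives a 1.6-fold higher number from compound 3 to compound 4 (0.20 log units; within the scatter), so this exchange, ortho to a methoxy group, no longer brings the clear gain seen without the second methoxy group: the same change on two cores in this assay, an at least 3.0-fold lower number (0.48 log units; beyond the scatter) from compound 1 to compound 2 and a 1.6-fold higher number (0.20 log units; within the scatter) from compound 3 to compound 4, at least 4.7-fold (0.67 log units) apart, beyond the scatter of two such steps. Methoxy in place of hydrogen still counts when the amino group is present, with a 3.8-fold lower number from compound 2 to compound 4 (0.57 log units; beyond the scatter), but the size of that step differs from the one seen with the nitro group: the same change on two cores in this assay, an at least 17-fold lower number (1.25 log units; beyond the scatter) from compound 1 to compound 3 and a 3.8-fold lower number (0.57 log units; beyond the scatter) from compound 2 to compound 4, at least 4.7-fold (0.67 log units) apart, beyond the scatter of two such steps. Both comparisons are bounded rather than exact, since compound 1 gives only a limit: the limit of > 100000 nM in this assay, at which 1 of the 4 values shown sits.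

Going by these compounds, how a hydroxyl, an acetamide or a dimethylamino group would behave at this position remains open. So does whether the dependence between the two changes would hold with an ethoxy group in place of the methoxy groups.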